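Aryl exchange from compound 2 to compound 3

A few compounds are considered here, and "the series" means these few. Any claim that something is new, unique, unknown or untested is made for them only; others in the source may bear on it.

Measured in a functional assay on MCF-A cells (Homo sapiens) for cytotoxicity; on this read-out higher numbers stand for weaker inhibition of growth and lower numbers for stronger inhibition of growth:
- Compound 1 `COc1ccc(C2=C(c3ccc(SC)cc3)CC3CCCN3C2=O)cc1OC(=O)C1CCCN1C(=O)OC(C)(C)C` gives 4000 nM
- Compound 2 `COc1ccc(C2=C(c3ccc(SC)cc3)CC3CCCN3C2=O)cc1Br` gives 6000 nM

Compound 2 at 6000 nM stands within the scatter of compound 1 at 4000 nM and the two values cannot be separated. The next compound to be read is compound 3 `CSc1ccc(C2=C(c3ccc(F)c(C)c3)C(=O)N3CCCC3C2)cc1` with the change 4-fluoro-3-methylphenyl in place of 3-bromo-4-methoxyphenyl on a double-bonded ring carbon in which 4-fluoro-3-methylphenyl replaces 3-bromo-4-methoxyphenyl on a double-bonded ring carbon. Among the compounds with values here, no measured step shows the size of such an exchange. In this assay no step beyond the scatter is therefore expected, and neither direction is favoured. The estimated change is a 1.2-fold lower number from compound 2 to compound 3 (0.08 log units; within the scatter) and it stays inside the scatter. Within the data shown here, the range is kept wide since only two values anchor it. For compound 3 the expected value is 5000 nM (estimated range 1800 nM to 14000 nM).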

Compound 3, concentration for 50% growth inhibition: 500 nM
Beside the measured number, compound 3's estimate is 10-fold (1.00 log units) above it; measured number below the stated range.
By their numbers in this assay, from the lowest: compound 3; then compounds 1 and 2 (each within the scatter of the next).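

In this assay, within the data shown here, the exchange of 3-bromo-4-methoxyphenyl for 4-fluoro-3-methylphenyl on the double-bonded ring carbon gives a 12-fold lower number from compound 2 to compound 3 (1.08 log units; beyond the scatter) and is the first step that stands beyond the scatter. Growth inhibition thus responds strongly to the aryl group at this position, with the 4-(methylsulfanyl)phenyl group and the rest of the shared core unchanged. No supporting data bear on the reason for this step.

Both substituents on the aryl group differ at once, so the compounds shown do not separate the part played by the fluorine from that of the methyl, or the loss of the bromine from that of the methoxy. Also open, going by these compounds, is how this aryl group responds to an amine or a carboxylic acid as substituent, and whether plain 4-fluorophenyl would hold the number of compound 3.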